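Swapping a Pyridyloxy Group for Methylsulfanyl on a Nucleoside

The source may report more compounds than this note shows. Statements on the series, on what has been measured and on what is new or still open speak of the compounds shown alone.

Three compounds sharing one core have been measured in a functional assay on HL-60 cells (Homo sapiens) for inhibition, with a stated time of 72 h; a higher number here means a weaker inhibitor, a lower number a stronger inhibitor:

Compound 1, `OC[C@H]1O[C@@H](n2cnc3c(COc4ccccn4)ncnc32)[C@H](O)[C@@H]1O`, gives 12000 nM.
Compound 2, `COCc1ncnc2c1ncn2[C@@H]1O[C@H](CO)[C@@H](O)[C@H]1O`, gives 13000 nM.
Compound 3, `OC[C@H]1O[C@@H](n2cnc3c(CN4CCCCC4)ncnc32)[C@H](O)[C@@H]1O`, gives 6900 nM.

Compound 1 has the second highest of the three numbers; its nearest neighbour is compound 2, a 1.1-fold higher number from compound 1 to compound 2 (0.03 log units; within the scatter), and the furthest is compound 3, a 1.7-fold lower number from compound 1 to compound 3 (0.24 log units; within the scatter). All three values thus sit within the usual scatter of one another.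

Compound 4, `CSCc1ncnc2c1ncn2[C@@H]1O[C@H](CO)[C@@H](O)[C@H]1O`, is the next step from compound 1: methylsulfanyl in place of (pyridin-2-yl)oxy on a saturated chain carbon bound to an aromatic carbon. For the measured compounds named here, the closest precedent is the step from compound 1 to compound 2, where a small methyl took the place of the pyridin-2-yl on the same oxygen, giving a 1.1-fold higher number from compound 1 to compound 2 (0.03 log units; within the scatter). The step of a 1.9-fold lower number from compound 2 to compound 3 (0.28 log units; within the scatter), which exchanges a small group for a ring at the same place, is likewise within the scatter. Going by the values given here, with every exchange at this position so far leaving the number essentially unchanged, no step beyond the scatter is expected in this assay for compound 4, in either direction.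

The estimate for compound 4 is therefore 11000 nM, with a range of 5000 nM to 25000 nM, meaning an expected step of a 1.1-fold lower number from compound 1 to compound 4 (0.04 log units; within the scatter).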

Compound 4, half-maximal inhibitory concentration: 13400 nM
Compound 4: the middle estimate sits 1.2-fold (0.09 log units) below what was measured; low and high end bracket the measured number.
By their numbers in this assay, from the lowest: compounds 3, 1, 2 and 4 (each within the scatter of the next).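

In this assay, for the compounds shown here, replacing (pyridin-2-yl)oxy with methylsulfanyl removes the aromatic ring and puts sulfur at this place for the first time, yet it gives a 1.1-fold higher number from compound 1 to compound 4 (0.05 log units; within the scatter). The closest comparison, methylsulfanyl in place of methoxy, exchanges oxygen for sulfur and keeps the methyl, and it gives a 1.0-fold higher number from compound 2 to compound 4 (0.01 log units; within the scatter). Methylsulfanyl in place of piperidin-1-yl gives a 1.9-fold higher number from compound 3 to compound 4 (0.29 log units; within the scatter), so across these four compounds, no exchange on this saturated chain carbon moves the number beyond the scatter, whether the group carries oxygen, nitrogen or sulfur, and whether or not it holds a ring.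

No supporting measurement bears on why the number stays put. On these data alone, whether a carboxylic acid, a primary amine or a longer alkyl chain at this place would produce a step beyond the scatter remains open.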